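The source may report more compounds than this note shows. Statements on the series, on what has been measured and on what is new or still open speak of the compounds shown alone.

Series notes. Compound 1 `N/C(=N\NC(=S)N1CCOCC1)c1ccccn1`, compound 2 `N/C(=N\NC(=S)N1CCCC1)c1ccc(F)cn1` and compound 3 `N/C(=N\NC(=S)N1CCSCC1)c1ccc(F)cn1` share a core and differ in the ring on the thiocarbonyl carbon and in the pyridine substitution. In a functional assay on A-375 cells (Homo sapiens) for cytotoxicity, read by MTT assay, with a stated time of 72 h, tested at 30 uM (on this read-out lower numbers stand for less inhibition of growth and higher numbers for more inhibition of growth at the one concentration tested), compound 1 gives 15%, compound 2 gives 83.2% and compound 3 gives 78.7%. Compound 3 stands second of the three numbers: its gap to compound 2 is within the scatter, while compound 1 lies far lower, beyond the scatter.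

Compound 4 `N/C(=N\NC(=S)N1CCOCC1)c1ccc(F)cn1` is to be measured in this assay. It differs from compound 3 by morpholin-4-yl in place of thiomorpholin-4-yl on a thiocarbonyl carbon. Within the data shown here, the one measured step that bears on a ring exchange at this position is a number 4.5 percentage points lower from compound 2 to compound 3 (within the scatter), which was within the scatter. Among the measured compounds shown here, no measured step isolates the exchange of thiomorpholin-4-yl for morpholin-4-yl; compound 1 carries morpholin-4-yl but also lacks the fluorine, so its low value cannot be assigned to the ring alone. A step of a number 4.7 percentage points lower from compound 3 to compound 4 (within the scatter) is therefore expected, small and not beyond the scatter. Compound 4 is estimated at 74%, within 48% to 90%.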

Compound 4, percent growth inhibition at one concentration: 85.9%
Compound 4: the middle estimate sits 11.9 percentage points below what was measured; the range from low to high includes it.
By their numbers in this assay, from the lowest: compound 1; then compounds 3, 2 and 4 (each within the scatter of the next).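

In this assay, the step with morpholin-4-yl held constant isolates fluoro in place of hydrogen on an aromatic carbon: a number 70.9 percentage points higher from compound 1 to compound 4 (beyond the scatter). The low value of compound 1 therefore goes with the hydrogen in this pair, and the morpholin-4-yl ring on the thiocarbonyl carbon is compatible with a high value when the fluoro group is present. With the fluoro group in place, the ring exchanges give a number 7.2 percentage points higher from compound 3 to compound 4 (within the scatter) and a number 2.7 percentage points higher from compound 2 to compound 4 (within the scatter), so the morpholin-4-yl, thiomorpholin-4-yl and pyrrolidin-1-yl rings cannot be told apart on this read-out, and nothing available accounts for either the large step or the small ones.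

On these data alone, whether the fluoro step has a similar size with the thiomorpholin-4-yl or pyrrolidin-1-yl ring remains open. So does whether chloro or methoxy could stand in place of fluoro, or an open-chain dimethylamino group in place of the ring.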